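A Hydroxy Group Added to Compound 1

This account rests on a few compounds, and the source may have more. Where it says the series, first, only, none or still open, it means among the compounds named here.

In an ADME assay on L6 cells (Rattus norvegicus) for cytotoxicity (on this read-out lower numbers stand for stronger inhibition and higher numbers for weaker inhibition), compound 1 `N=C(N)c1ccc(-c2cc3cc(C(=N)N)ccc3o2)cc1` gives 1900 nM. Among the compounds with values here, the only other measured compound, compound 2 `c1c[nH]c(-c2ccc(-c3cc4cc(-c5ncc[nH]5)ccc4o3)cc2)n1`, gives 3300 nM. These two numbers lie within the scatter of each other, so compound 1 cannot be ranked against compound 2 on this evidence. Within the data shown here, no measured pair differs in one place only, which leaves no direct precedent for the next change.

Compound 3 `N=C(N)c1ccc(-c2cc3cc(C(=N)N)ccc3o2)c(O)c1` is compound 1 with hydroxy in place of hydrogen on an aromatic carbon, ortho to a large group and meta to a group of 3 heavy atoms: hydroxy in place of hydrogen on an aromatic carbon. The data do not show what this substitution does in this assay. The only available hint is that compound 1 at 1900 nM stays within the scatter of the structurally different compound 2 at 3300 nM, which is weak support for expecting little movement. The expected change is small, a 1.3-fold higher number from compound 1 to compound 3 (0.12 log units; within the scatter), and no shift beyond the scatter is expected. In this assay the estimate for compound 3 is 2500 nM, with an expected range from 700 nM to 9000 nM.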

Compound 3, half-maximal inhibitory concentration: 33300 nM
Estimate against measurement, compound 3: 13-fold (1.12 log units) below, outside the stated range (above it).
By their numbers in this assay, from the lowest: compounds 1 and 2 (each within the scatter of the next); then compound 3.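

In this assay, hydroxy in place of hydrogen on an aromatic carbon gives an 18-fold higher number from compound 1 to compound 3 (1.24 log units; beyond the scatter), which shows that at this place, ortho to a large group and meta to a group of 3 heavy atoms, the entry of 1 heavy atom is enough to move the read-out well beyond the scatter, toward weaker inhibition. Within the data shown here, the earlier compounds held no pair differing in one place, so this is the first direct reading of a single change on the core of compound 1, and it shows that this position is not indifferent to substitution in this assay. Nothing at hand gives a measured reason for a step of this size.

The compounds shown carry only hydrogen or hydroxy on this carbon, so whether methoxy or fluorine there would move the number as far remains open. Also open, as far as these compounds go, is whether hydroxy on another aromatic carbon of the core of compound 1 would give a step of similar size, or whether the effect belongs to this place alone.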